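The compounds below may be only part of what the source reports. "The series", "measured", "known", "first", "only" and "open" are said of these compounds alone.

Of the compounds shown here, two that share one core have so far been measured in a functional assay on CHO cells for positive allosteric modulation of metabotropic glutamate receptor 2 (Homo sapiens), with a stated time of 30 min; on this read-out higher numbers stand for an effect only at larger amounts of compound and lower numbers for an effect already at smaller amounts. Compound 1 `CC(C)CCn1ccc(N2CCC(c3ccccc3)CC2)c(C#N)c1=O` gives 102 nM in this assay, and compound 2 `CC(C)Cn1ccc(N2CCC(c3ccccc3)CC2)c(C#N)c1=O` gives 282 nM. Among the compounds with values here, of these two numbers, compound 2 stands highest; its only neighbour is compound 1, and the one measured step, a 2.8-fold higher number from compound 1 to compound 2 (0.44 log units; beyond the scatter), goes with isopropyl in place of isobutyl on a saturated chain carbon bound to an aromatic nitrogen.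

Compound 3 `N#Cc1c(N2CCC(c3ccccc3)CC2)ccn(CC2CCC2)c1=O` has not yet been measured. It differs from compound 2 in one place: cyclobutyl in place of isopropyl on a saturated chain carbon bound to an aromatic nitrogen. Within the data shown here, the only step that bears on this change is a 2.8-fold higher number from compound 1 to compound 2 (0.44 log units; beyond the scatter), in which a smaller group on that saturated chain carbon went with a higher number in this assay, a modest step beyond the scatter. The group entering in compound 3 is again larger than the one leaving, so a step back in the other direction, of modest size at most, is expected rather than none. Compound 3 is therefore estimated to give 170 nM in this assay, with a range from 60 nM to 480 nM. That estimate corresponds to an expected step of a 1.7-fold lower number from compound 2 to compound 3 (0.22 log units; within the scatter).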

Compound 3, half-maximal effective concentration: 55 nM
The estimate for compound 3 lay 3.1-fold (0.49 log units) above the measured number, and the stated range ends above it.
By their numbers in this assay, from the lowest: compounds 3 and 1 (each within the scatter of the next); then compound 2.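

In this assay, cyclobutyl on a saturated chain carbon bound to an aromatic nitrogen gives a 5.1-fold lower number from compound 2 to compound 3 (0.71 log units; beyond the scatter) and so shows that this place accepts a four-membered non-aromatic ring of carbon only without any loss against the open-chain groups. Against isobutyl the same ring gives a 1.9-fold lower number from compound 1 to compound 3 (0.27 log units; within the scatter) and so cannot be told apart from it on this read-out, which leaves isopropyl in compound 2 as the one group of the three that stands apart, with steps beyond the scatter to both others. Nothing on hand accounts for this result or says why the ring and the longer branched chain read alike.

From the compounds shown here alone, how a smaller or larger ring, such as cyclopropyl or cyclopentyl, would read at this place remains open, and so does a chain carrying an ether oxygen or an amine. Going by these compounds, it is also open whether the order among isopropyl, isobutyl and cyclobutyl would hold if the phenyl group on the shared core carried a substituent such as fluorine.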